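Arylthiosemicarbazones of the quinoline aldehyde: the ortho-methyl analogue

The source may report more compounds than this note shows. Statements on the series, on what has been measured and on what is new or still open speak of the compounds shown alone.

Compound 3, `N#Cc1ccc(NC(=S)N/N=C/c2ccc3ccccc3n2)cc1`, gives 4660 nM in a functional assay on HL-60 cells (Homo sapiens) for antiproliferative activity, read by sulforhodamine B assay, with a stated time of 72 h (on this read-out lower numbers stand for stronger inhibition and higher numbers for weaker inhibition), and stands lowest of the two numbers reported there. Compound 1, `NC(=S)N/N=C/c1ccc2ccccc2n1`, is the unsubstituted parent; in this assay compound 1 returns only a limit of the assay, > 100000 nM. Compound 2, `COc1cccc(NC(=S)N/N=C/c2ccc3ccccc3n2)c1`, gives 71200 nM in this assay.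

The step to compound 4, `Cc1ccccc1NC(=S)N/N=C/c1ccc2ccccc2n1`, is 2-methylphenyl in place of 4-cyanophenyl on an amide-type nitrogen. The measured steps on the same nitrogen are an at least 21-fold lower number from compound 1 to compound 3 (1.33 log units; beyond the scatter), a 15-fold lower number from compound 2 to compound 3 (1.18 log units; beyond the scatter) and the small or absent effect an at least 1.4-fold lower number from compound 1 to compound 2 (0.14 log units; that floor lies within the scatter). Of these, the aryl-to-aryl exchange a 15-fold lower number from compound 2 to compound 3 (1.18 log units; beyond the scatter) bears most directly on the new step, since it too replaces one ring substituent by another on the amide-type nitrogen. Compound 4 loses the 4-cyanophenyl that carried the large gain and takes a 2-methylphenyl with no hydrogen-bond acceptor; the closest measured example of an aryl group without the nitrile, compound 2, sits well above compound 3. A clear move to a higher number is therefore expected for compound 4 in this assay, a step of about a 7.5-fold higher number from compound 3 to compound 4 (0.88 log units; beyond the scatter), putting it nearer compound 2 than compound 3. Compound 4 is estimated at 35000 nM, expected within 7000 nM to 150000 nM, with some chance that only a limit is returned.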

Compound 4, half-maximal inhibitory concentration: 73200 nM
Beside the measured number, compound 4's estimate is 2.1-fold (0.32 log units) below it; the measured number falls inside the stated range.
By their numbers in this assay, from the lowest: compound 3; then compounds 2 and 4 (each within the scatter of the next). At a limit, above all of these: compound 1.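

In this assay the 2-methylphenyl of compound 4 does not hold the level of the 4-cyanophenyl, with a 16-fold higher number from compound 3 to compound 4 (1.20 log units; beyond the scatter) as the step on the amide-type nitrogen, so a second aryl group without the nitrile now stands well away from compound 3. 2-Methylphenyl and 3-methoxyphenyl cannot be told apart at this position, with a 1.0-fold higher number from compound 2 to compound 4 (0.01 log units; within the scatter) as their step, which leaves 4-cyanophenyl as the only group shown that separates from the others and ties the low number of compound 3 to that group and not to an aryl ring as such; compounds 2 and 4 both go against any general gain from an aryl ring. Going by these compounds alone, compound 1 has only a limit, and an at least 1.3-fold lower number from compound 1 to compound 4 (0.13 log units; that floor lies within the scatter) is a floor that gives no size for the step from the parent: the limit of > 100000 nM in this assay, at which 1 of the 4 values shown sits.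

From the compounds shown here alone, whether the low number of compound 3 follows the nitrile itself or the 4-cyanophenyl as a whole stays open. Going by these compounds, how a carboxylic acid, an amine or a longer chain in place of the nitrile would read in this assay is also open.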